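Aryl variation on the shared core: hydroxyphenyl step

The source may report more compounds than this note shows. Statements on the series, on what has been measured and on what is new or still open speak of the compounds shown alone.

Measured so far in a functional assay, with a stated time of 90 s; a lower number here means a stronger inhibitor, a higher number a weaker inhibitor:
compound 1 `Cc1nc2c3ccccc3ccc2c2nc3c(ccc4ccccc43)c(-c3cccnc3)c12` gives 156 ug/mL
compound 2 `Cc1nc2c3ccccc3ccc2c2nc3c(ccc4ccccc43)c(-c3cc([N+](=O)[O-])ccc3N)c12` gives 110 ug/mL
compound 3 `Cc1nc2c3ccccc3ccc2c2nc3c(ccc4ccccc43)c(-c3ccccc3N)c12` gives 125 ug/mL

Compound 3 holds the second highest of the three numbers; the nearest is compound 2 with a 1.1-fold higher number from compound 2 to compound 3 (0.06 log units; within the scatter), the furthest compound 1 with a 1.2-fold lower number from compound 1 to compound 3 (0.10 log units; within the scatter), both within the scatter. Compound 4 `Cc1nc2c3ccccc3ccc2c2nc3c(ccc4ccccc43)c(-c3ccc(O)cc3)c12` is not yet measured; the change is 4-hydroxyphenyl in place of 2-aminophenyl on an aromatic carbon. Going by the values given here, every step across this position so far, a 1.4-fold lower number from compound 1 to compound 2 (0.15 log units; within the scatter) and a 1.2-fold lower number from compound 1 to compound 3 (0.10 log units; within the scatter), stayed within the scatter, and no step on a hydroxyl group has been measured. In this assay the expected step is therefore none beyond the scatter, no change at the digits printed from compound 3 to compound 4 (within the scatter). Compound 4 is estimated at 125 ug/mL, with a range from 65 ug/mL to 240 ug/mL.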

Compound 4, half-maximal inhibitory concentration: 99 ug/mL
Beside the measured number, compound 4's estimate is 1.3-fold (0.10 log units) above it, within the range that was stated.
By their numbers in this assay, from the lowest: compounds 4, 2, 3 and 1 (each within the scatter of the next).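

In this assay, going by these compounds alone, the 4-hydroxyphenyl group brings a hydroxyl to this position for the first time, and all three steps to it stay within the scatter: a 1.3-fold lower number from compound 3 to compound 4 (0.10 log units; within the scatter), a 1.1-fold lower number from compound 2 to compound 4 (0.05 log units; within the scatter) and a 1.6-fold lower number from compound 1 to compound 4 (0.20 log units; within the scatter). Pyridin-3-yl, 2-aminophenyl, 2-amino-5-nitrophenyl and 4-hydroxyphenyl therefore remain unseparated at this position. No evidence at hand bears on this result. Still open, going by these compounds, is whether a carboxylic acid or a longer chain on this aryl ring would give a step beyond the scatter. On these data alone, how 2-hydroxyphenyl would compare with 4-hydroxyphenyl is also open.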